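A few compounds are considered here, and "the series" means these few. Any claim that something is new, unique, unknown or untested is made for them only; others in the source may bear on it.

Series notes. The shared core is carried by compound 1 `C#CCSc1nnc(-c2cc(OC)c(OC)c(OC)c2)n1N1C(=O)c2ccccc2C1=O`, compound 2 `COc1cc(-c2nnc(SCC(=O)c3ccc(Cl)cc3)n2N2C(=O)c3ccccc3C2=O)cc(OC)c1OC`, compound 3 `COc1cc(-c2nnc(SCC(=O)c3ccccc3)n2N2C(=O)c3ccccc3C2=O)cc(OC)c1OC` and the not yet measured compound 4 `COc1ccc(C(=O)CSc2nnc(-c3cc(OC)c(OC)c(OC)c3)n2N2C(=O)c3ccccc3C2=O)cc1`. In a functional assay on PC-3M cells (Homo sapiens) for cytotoxicity, read by MTT assay, with a stated time of 48 h (on this read-out higher numbers stand for weaker inhibition and lower numbers for stronger inhibition), compound 1 gives > 200000 nM, which is a limit of the assay and not a number. In this assay compound 2 gives 20700 nM. In this assay compound 3 gives > 200000 nM, again a limit and not a number. Compound 3 thus stands at the limit of > 200000 nM in this assay, at which 2 of the 3 values shown sit, and its true position is open. The change to compound 4 is methoxy in place of hydrogen on an aromatic carbon. Within the data shown here, the step that bears on it is an at least 9.6-fold higher number from compound 2 to compound 3 (0.98 log units; beyond the scatter), the only exchange of a group on an aromatic carbon measured here; the step of an at least 9.6-fold lower number from compound 1 to compound 2 (0.98 log units; beyond the scatter) and the unreadable a step that the two limits leave unreadable from compound 1 to compound 3 add that the benzoyl chain without a group on that ring yields no number. Methoxy has no measured counterpart in this set, so the expected step is an at least 2.5-fold lower number from compound 3 to compound 4 (0.39 log units; beyond the scatter), with a sizeable chance that only a limit is returned. Compound 4 is expected at 80000 nM, within 15000 nM to 200000 nM.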

Compound 4, half-maximal inhibitory concentration: 32800 nM
Compound 4: the middle estimate sits 2.4-fold (0.39 log units) above what was measured, within the range that was stated.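

In this assay, among these compounds, chloro is no longer the only group on this ring to return a number, since methoxy, placed para to a large group, also does: an at least 6.0-fold lower number from compound 3 to compound 4 (0.78 log units; beyond the scatter). The two groups cannot be told apart at this position, as the exchange stays within the scatter: a 1.6-fold higher number from compound 2 to compound 4 (0.20 log units; within the scatter). The (4-methoxyphenyl)carbonyl chain also reads as a gain over the ethynyl end of the chain, as the (4-chlorophenyl)carbonyl chain did, while the unsubstituted benzoyl chain gives no number: an at least 6.0-fold lower number from compound 1 to compound 4 (0.78 log units; beyond the scatter).

On these data alone, compound 3 remains a limit of the assay and not a number, so the true size of the step to methoxy stays open: the limit of > 200000 nM in this assay, at which 2 of the 4 values shown sit. Whether a smaller atom such as fluoro, or an amine or a carboxylic acid, at this ring position also returns a number remains open.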